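The source may report more compounds than this note shows. Statements on the series, on what has been measured and on what is new or still open speak of the compounds shown alone.

Among the measured compounds shown here, in a functional assay on HT-29 cells (Homo sapiens) for antiproliferative activity, read by sulforhodamine B assay, with a stated time of 48 h (a higher number here means a weaker inhibitor, a lower number a stronger inhibitor), three sulfonamides with a shared core have numbers so far. Compound 1 `CCc1ccccc1NS(=O)(=O)c1ccc(N2CCNC2=O)cc1` gives 240 nM, compound 2 `O=C1NCCN1c1ccc(S(=O)(=O)Nc2ccc(I)cc2)cc1` gives 650 nM, and compound 3 `Cc1cc(C)cc(NS(=O)(=O)c2ccc(N3CCNC3=O)cc2)c1` gives 82 nM, the lowest of the three. The next compound, compound 4 `Cc1ccc(C)c(NS(=O)(=O)c2ccc(N3CCNC3=O)cc2)c1`, has 2,5-dimethylphenyl in place of 3,5-dimethylphenyl on a sulfonamide nitrogen.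

Changes of the group on this nitrogen have already moved the number. There is a 2.9-fold lower number from compound 1 to compound 3 (0.47 log units; beyond the scatter), where 3,5-dimethylphenyl replaces 2-ethylphenyl, and a 7.9-fold lower number from compound 2 to compound 3 (0.90 log units; beyond the scatter), where it replaces 4-iodophenyl. Both steps are modest. The new group shares the "2" of its name with the 2-ethylphenyl of compound 1, which gives 240 nM, so a partial move towards that number seems likely, though one pair offers only thin support. In this assay the expected change is small, towards a higher number and a weaker inhibitor: a 1.8-fold higher number from compound 3 to compound 4 (0.26 log units; within the scatter). For compound 4 the estimated value is 150 nM, with an expected range from 60 nM to 360 nM.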

Compound 4, half-maximal inhibitory concentration: 46 nM
Compound 4: the middle estimate sits 3.3-fold (0.51 log units) above what was measured; the measured number lies below the stated range.
By their numbers in this assay, from the lowest: compounds 4 and 3 (each within the scatter of the next); then compound 1; then compound 2.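

In this assay, 2,5-dimethylphenyl and 3,5-dimethylphenyl have the same atoms joined differently, and swapping one for the other on the sulfonamide nitrogen gives a 1.8-fold lower number from compound 3 to compound 4 (0.25 log units; within the scatter), so this assay does not separate the two groups. Among the compounds shown here, the 2,5-dimethylphenyl group also stands clear of the other two groups, with a 5.2-fold lower number from compound 1 to compound 4 (0.72 log units; beyond the scatter) against 2-ethylphenyl and a 14-fold lower number from compound 2 to compound 4 (1.15 log units; beyond the scatter) against 4-iodophenyl, the largest step at this position so far. No measurement here explains these differences.

The compounds shown leave open whether both methyl groups are needed to keep a number close to the one compound 4 gives (46 nM). They also leave open how a phenyl ring carrying an amine or a carboxylic acid would behave on this nitrogen.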